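This account rests on a few compounds, and the source may have more. Where it says the series, first, only, none or still open, it means among the compounds named here.

Compound 1 `O=C(/C=C\Nc1ccc(F)cc1)c1nc(-c2ccc(F)cc2)n2ccccc12` in a functional assay on MDA-MB-231 cells (Homo sapiens) for cytotoxicity, read by MTT assay, with a stated time of 48 h (a higher number here means a weaker inhibitor, a lower number a stronger inhibitor), gives 25100 nM.
Compound 2 `COc1ccc(N/C=C\C(=O)c2nc(-c3ccc(F)cc3)n3ccccc23)cc1OC` in this assay gives > 30000 nM, which is a limit of the assay and not a number.

Going by the values given here, compound 2 thus stands at the limit of > 30000 nM in this assay, at which 1 of the 2 values shown sits, and the single measured step, an at least 1.1-fold higher number from compound 1 to compound 2 (0.07 log units; that floor lies within the scatter), says little more than that the exchange on the amine nitrogen did not sharpen the inhibition. Compound 3 `Cc1cc2cc(N/C=C\C(=O)c3nc(-c4ccc(F)cc4)n4ccccc34)ccc2[nH]1` carries 2-methyl-1H-indol-5-yl in place of 3,4-dimethoxyphenyl on an amine nitrogen. Among the compounds with values here, no measured step tests an indolyl group at this place, so the one step with a related exchange is the only guide, and no shift beyond the scatter is expected. Compound 3 is expected near 30000 nM, within 10000 nM to 90000 nM. This estimate means a step of a number no higher from compound 2 to compound 3 (the limit leaves the size open), most likely reported again as a limit.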

Compound 3, half-maximal inhibitory concentration: > 30000 nM
Compound 3 ended at the assay's limit; the forecaster's own chance of this, stated with the estimate: 55%; the middle value lies on the limit itself.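

In this assay, placing 2-methyl-1H-indol-5-yl on the amine nitrogen in place of 4-fluorophenyl gives an at least 1.1-fold higher number from compound 1 to compound 3 (0.07 log units; that floor lies within the scatter). The step from compound 2 to compound 3 cannot be read, so the two groups cannot be ranked. A group with a five-membered aromatic ring now joins 3,4-dimethoxyphenyl, and compound 2 and compound 3 both stand at a limit of the assay, not at a number: the limit of > 30000 nM in this assay, at which 2 of the 3 values shown sit.

From the compounds shown here alone, whether a simple alkyl chain or a morpholine-bearing phenyl on this nitrogen would give a lower number remains open. So does the effect of any change to the shared core.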